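Solubility notes: triazolyl replacing butyl on the shared core

The source may report more compounds than this note shows. Statements on the series, on what has been measured and on what is new or still open speak of the compounds shown alone.

Compound 2 `CCCCc1nc(C(C)(C)C)nc2nc(N)c(C#N)c(N)c12` stands at the low end of the two numbers in hand: in a physicochemical assay for solubility, in phosphate buffer, with a stated time of 18 h (a lower number here means a less soluble compound, a higher number a more soluble compound), compound 2 gives 6000 nM, while compound 1 `N#Cc1c(N)nc2nc(C3CCCC3)ncc2c1N` gives 89000 nM, a gap beyond the scatter. The change to compound 3 `CC(C)(C)c1nc(-c2ncn[nH]2)c2c(N)c(C#N)c(N)nc2n1` is 1H-1,2,4-triazol-5-yl in place of butyl on an aromatic carbon, on an aromatic carbon of a six-membered aromatic ring with 2 nitrogen, part of a fused or bridged system of two rings. Within the data shown here, no step between measured compounds covers this change. Compound 3 is expected to give a higher number in this assay, estimated at 40000 nM, in the range 10000 nM to 150000 nM, a step of a 6.7-fold higher number from compound 2 to compound 3 (0.82 log units; beyond the scatter).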

Compound 3, solubility: 64500 nM
The estimate for compound 3 lay 1.6-fold (0.21 log units) below the measured number, within the range that was stated.
By their numbers in this assay, from the lowest: compound 2; then compounds 3 and 1 (each within the scatter of the next).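

In this assay, among these compounds, replacing butyl with 1H-1,2,4-triazol-5-yl gives an 11-fold higher number from compound 2 to compound 3 (1.03 log units; beyond the scatter), the first measured step on the shared core. With the tert-butyl group unchanged, this position on an aromatic carbon can hold a five-membered aromatic ring in place of a chain, and the step is large. Nothing measured here accounts for the size of this step.

Going by these compounds, whether the step belongs to the triazolyl ring or to the loss of butyl stays open. A methyl group, an amine or a phenyl ring at this position would separate the two.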